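Dimethylamino Added to a Benzyl Arm: Cytotoxicity Outlook

This account rests on a few compounds, and the source may have more. Where it says the series, first, only, none or still open, it means among the compounds named here.

Compound 1 `Cc1ccc2[nH]c(=O)c(CN(Cc3ccccc3)Cc3ccc(C(C)(C)C)cc3)cc2c1` in a toxicity assay on MDCK cells (Canis lupus familiaris) for cytotoxicity, read by crystal violet staining, with a stated time of 48 h (on this read-out higher numbers stand for lower toxicity in this test and lower numbers for higher toxicity in this test), gives only a limit, > 5000 nM. Compound 2 `CCc1ccc2[nH]c(=O)c(CN(Cc3ccc(F)cc3)Cc3ccc(-c4ccccc4)cc3)cc2c1` in this assay likewise gives only a limit, > 5000 nM.

On the numbers shown, compound 1 stands at the limit, where both values sit (the limit of > 5000 nM in this assay, at which 2 of the 2 values shown sit). Compound 3 `Cc1ccc2[nH]c(=O)c(CN(Cc3ccc(N(C)C)cc3)Cc3ccc(C(C)(C)C)cc3)cc2c1` differs from compound 1 by dimethylamino in place of hydrogen on an aromatic carbon. Going by the values given here, with no step between measured compounds to lean on, the expected step is a step that the limit leaves unreadable from compound 1 to compound 3, none beyond the scatter. Compound 3 is therefore expected to give 8000 nM, with a range of 3500 nM to 25000 nM, most likely again reported as a limit.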

Compound 3, half-maximal cytotoxic concentration: > 5000 nM
Compound 3: no number, only a limit; the forecaster's own chance of this, stated with the estimate: 80%; the middle value lies beyond the limit too.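

Compound 1 and compound 3 are both reported in this assay only as limits, not as numbers, so no step can be read between them. Whether dimethylamino shifts the toxicity at all stays open, with every value at one limit: the limit of > 5000 nM in this assay, at which 3 of the 3 values shown sit.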